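The compounds below may be only part of what the source reports. "The series", "measured", "known", "first", "only" and "open" are said of these compounds alone.

Compound 1 `N#Cc1ccc(/C=C/S(=O)(=O)Cc2ccc(Nc3ncnc4ccccc34)cc2)cc1`: > 100000 nM (a limit of the assay, not a number)
Compound 2 `O=S(=O)(/C=C/c1ccc(Cl)cc1Cl)Cc1ccc(Nc2ncnc3ccccc23)cc1`: 5000 nM
Compound 3 `O=S(=O)(/C=C/c1ccc(C(F)(F)F)cc1F)Cc1ccc(Nc2ncnc3ccccc23)cc1`: 100000 nM

In a functional assay on NCI/ADR-RES cells (Homo sapiens) for inhibition (a higher number here means a weaker inhibitor of growth, a lower number a stronger inhibitor of growth), compound 2 stands lowest at 5000 nM, and it is the best growth inhibitor of these three. Compound 4 `O=S(=O)(/C=C/c1ccc(Cl)cc1Cl)Cc1ccc(Nc2ncnc3cc(Cl)ccc23)cc1` keeps all of compound 2 except for one change in the shared core: chloro in place of hydrogen on an aromatic carbon. The measured steps, an at least 20-fold lower number from compound 1 to compound 2 (1.30 log units; beyond the scatter) and a 20-fold higher number from compound 2 to compound 3 (1.30 log units; beyond the scatter), are both large, but both swap the aromatic group on the double-bonded chain. Neither touches the carbon that changes here, so they show only that this series can respond strongly to small swaps. The expected 1.3-fold lower number from compound 2 to compound 4 (0.10 log units; within the scatter) is therefore not beyond the scatter, with a wide margin either way. For compound 4 the estimated value is 4000 nM, within an expected range of 1000 nM to 20000 nM.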

Compound 4, concentration for 50% growth inhibition: > 100000 nM
Compound 4: a limit, no number; the forecaster's own chance of this, stated with the estimate: 10%; middle value at least 25-fold (1.39 log units) away from the limit.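

Until now only the aromatic group on the double-bonded chain had varied, but chloro in place of hydrogen on an aromatic carbon of the shared core gives an at least 20-fold higher number from compound 2 to compound 4 (1.30 log units; beyond the scatter). A single added chlorine at this position is therefore enough to cost compound 2 its growth inhibition. In this assay compound 4 gives > 100000 nM, a limit of the assay and not a number: the limit of > 100000 nM in this assay, at which 2 of the 4 values shown sit.

The compounds shown leave open whether fluoro, methoxy or an amine on this carbon would do the same. They also leave open whether chloro here would have the same result with other aromatic groups on the chain.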